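Compound 3 to compound 4: adding a ring-bearing group

The compounds below may be only part of what the source reports. "The series", "measured", "known", "first", "only" and "open" are said of these compounds alone.

In an ADME assay on BaF3 cells (Mus musculus) for antiproliferative activity, read by CCK-8 assay, with a stated time of 72 h (on this read-out higher numbers stand for weaker inhibition of growth and lower numbers for stronger inhibition of growth), compound 3 (`O=C(NCCSc1ccc2c(/C=C/c3ccccn3)n[nH]c2c1)c1cccc(C(F)(F)F)c1`) gives 1500 nM. That value lies within the scatter of compound 2 (`Cc1cn(Cc2ccc(NC(=O)CCSc3ccc4c(/C=C/c5ccccn5)n[nH]c4c3)cc2C(F)(F)F)cn1`) at 1990 nM, while compound 1 (`CC1CCN(Cc2ccc(NC(=O)CCSc3ccc4c(/C=C/c5ccccn5)n[nH]c4c3)cc2C(F)(F)F)CC1`) at 4170 nM shows a number beyond the scatter from compound 3.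

Compound 4 (`CN1CCN(Cc2ccc(C(=O)NCCSc3ccc4c(/C=C/c5ccccn5)n[nH]c4c3)cc2C(F)(F)F)CC1`) differs from compound 3 by (4-methylpiperazin-1-yl)methyl in place of hydrogen on an aromatic carbon. Going by the values given here, no measured step adds such a group directly. The nearest evidence is a 2.1-fold lower number from compound 1 to compound 2 (0.32 log units; beyond the scatter), a modest step that exchanges one ring for another on a saturated chain carbon. Compound 1 and compound 2 also differ from compound 3 in the chain joining the amide to the core, so that step is only a loose guide.

With compound 2 at 1990 nM and compound 1 at 4170 nM, both carrying a ring on such a chain carbon, a small rise in the number is expected rather than a fall. The expected change is a 1.5-fold higher number from compound 3 to compound 4 (0.17 log units; within the scatter). For compound 4 the estimated value is 2200 nM, with an expected range of 800 nM to 5500 nM.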

Compound 4, concentration for 50% growth inhibition: 4800 nM
The estimate for compound 4 lay 2.2-fold (0.34 log units) below the measured number; the measured number falls inside the stated range.
By their numbers in this assay, from the lowest: compounds 3 and 2 (each within the scatter of the next); then compounds 1 and 4 (each within the scatter of the next).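

In this assay the (4-methylpiperazin-1-yl)methyl group, on an aromatic carbon ortho to a trifluoromethyl group and para to a large group, gives a 3.2-fold higher number from compound 3 to compound 4 (0.51 log units; beyond the scatter) and thus weaker inhibition of growth than hydrogen at that carbon. The earlier step exchanged one ring for another on a saturated chain carbon, whereas this one sets a substituent against hydrogen on the aromatic carbon and shows that this position is sensitive to the change. No accompanying measurement accounts for the rise.

Open, from the compounds shown here alone, is whether the rise goes with the ring itself or with any group at this carbon; a dimethylaminomethyl or a plain methyl group there would separate the two. Also open, going by these compounds, is whether the same step holds with the amide and chain arrangement of compound 1 and compound 2.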